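Removing the Methoxy Group: From Compound 3 to Compound 4

The source may hold more compounds than are shown below. What is called first, only, known or untested is meant among the compounds shown, and "the series" means these compounds.

Compound 3 `COc1ccccc1/C=N/c1c(C)n(C)n(-c2ccccc2)c1=O` gives the lowest number of the three measured compounds in a functional assay on HT-29 cells (Homo sapiens) for cytotoxicity, read by MTT assay, with a stated time of 72 h (a higher number here means a weaker inhibitor, a lower number a stronger inhibitor), at 70800000 nM. Compound 1 `CCOc1cccc(/C=N/c2c(C)n(C)n(-c3ccccc3)c2=O)c1` gives 295000000 nM in this assay, and compound 2 `Cc1c(/N=C/c2ccccc2Cl)c(=O)n(-c2ccccc2)n1C` gives 309000000 nM. For the measured compounds named here, the one single-point step among them, a 4.4-fold lower number from compound 2 to compound 3 (0.64 log units; beyond the scatter), shows that methoxy in place of chloro on an aromatic carbon went together with a modest but clear lowering of the number. Compound 4 `Cc1c(/N=C/c2ccccc2)c(=O)n(-c2ccccc2)n1C` differs from compound 3 by hydrogen in place of methoxy on an aromatic carbon, ortho to a large group. Going by the values given here, no measured pair shows this exact change; the nearest guide is the step in which the methoxy group arrived together with a lower number. Taking the methoxy away again is therefore expected to move the number back upward by a modest step, a 2.8-fold higher number from compound 3 to compound 4 (0.45 log units; beyond the scatter), on the strength of a 4.4-fold lower number from compound 2 to compound 3 (0.64 log units; beyond the scatter). Compound 4 is thus estimated at 200000000 nM, within a range from 70000000 nM to 500000000 nM.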

Compound 4, half-maximal inhibitory concentration: 851000000 nM
Beside the measured number, compound 4's estimate is 4.3-fold (0.63 log units) below it; the whole stated range lies below it.
By their numbers in this assay, from the lowest: compound 3; then compounds 1 and 2 (each within the scatter of the next); then compound 4.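

With hydrogen on this aromatic carbon, ortho to a large group, the number in this assay rises well above those of the substituted compounds: the change from 2-methoxyphenyl to phenyl is a large step (a 12-fold higher number from compound 3 to compound 4 (1.08 log units; beyond the scatter)). The other two substituted compounds also lie on the lower side of compound 4, by modest steps (a 2.8-fold higher number from compound 2 to compound 4 (0.44 log units; beyond the scatter); a 2.9-fold higher number from compound 1 to compound 4 (0.46 log units; beyond the scatter)), so chloro, ethoxy and methoxy each go with a lower number than hydrogen, and methoxy gives the largest step of the three. Nothing measured here accounts for this difference.

From the compounds shown here alone, whether a hydroxy group, an amine or a longer alkoxy chain at this place would go lower than methoxy remains open. So does whether the step from methoxy to hydrogen would keep its size on a different core.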